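The source may hold more compounds than are shown below. What is called first, only, known or untested is meant among the compounds shown, and "the series" means these compounds.

Two compounds of the series carry numbers in an ADME assay on MDCK cells (Canis lupus familiaris) for cytotoxicity, read by microscopy, with a stated time of 48 h; a lower number here means that less compound is tolerated, a higher number that more compound is tolerated. Compound 1 `C[C@H]1[C@H](NCc2cc(C3CC3)cs2)C[C@H]2C[C@@H]1C2(C)C` gives 25000 nM in this assay. Compound 2 `C[C@H]1[C@H](NCc2sccc2C2CCCCC2)C[C@H]2C[C@@H]1C2(C)C` gives 1560 nM in this assay, the lowest of the two numbers, with compound 1 standing well above it, beyond the scatter. Compound 3 `C[C@H]1[C@H](NCc2cccs2)C[C@H]2C[C@@H]1C2(C)C` follows from compound 2 by one change: hydrogen in place of cyclohexyl on an aromatic carbon. Among the compounds with values here, no measured step of this kind exists. Loss of the cyclohexyl is expected to raise the tolerated concentration, a step of a 13-fold higher number from compound 2 to compound 3 (1.11 log units; beyond the scatter) beyond the scatter. For orientation, compound 1 gives 25000 nM. Compound 3 is estimated at 20000 nM, in a range from 6000 nM to 60000 nM.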

Compound 3, minimum cytotoxic concentration: 25000 nM
For compound 3 the middle estimate is 1.3-fold (0.10 log units) below the measured one; measured number inside the range.
By their numbers in this assay, from the lowest: compound 2; then compounds 1 and 3 (each within the scatter of the next).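

In this assay, taking cyclohexyl off this aromatic carbon gives a 16-fold higher number from compound 2 to compound 3 (1.20 log units; beyond the scatter) and so ties the low tolerated concentration of compound 2 to that group at this place. Hydrogen in place of cyclopropyl on an aromatic carbon gives no change at the digits printed from compound 1 to compound 3 (within the scatter), so cyclopropyl, unlike cyclohexyl, leaves the number where the unsubstituted thiophene of compound 3 stands. No supporting data bear on why the cyclohexyl step is so large. Open, going by these compounds, is whether a carboxylic acid, an amine or a longer chain on this aromatic carbon would keep the number of compound 3 or pull it down as cyclohexyl does.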